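Dechlorination of the sulfonylguanidine aryl ring in fluoroquinolone analogues

This account rests on a few compounds, and the source may have more. Where it says the series, first, only, none or still open, it means among the compounds named here.

Of the compounds shown here, three have been measured in a functional assay on HL-60 cells (Homo sapiens) for antiproliferative activity, read by MTT assay, with a stated time of 72 h; on this read-out lower numbers stand for stronger inhibition and higher numbers for weaker inhibition. Compound 1 `N=C(NS(=O)(=O)c1ccccc1)N1CCN(c2cc3c(cc2F)c(=O)c(C(=O)O)cn3C2CC2)CC1` gives 43 nM. Compound 2 `CCn1cc(C(=O)O)c(=O)c2cc(F)c(N3CCN(C(=N)NS(=O)(=O)c4ccccc4Cl)CC3)cc21` gives 43 nM. Compound 3 `N=C(NS(=O)(=O)c1cccc(Cl)c1)N1CCN(c2cc3c(cc2F)c(=O)c(C(=O)O)cn3C2CC2)CC1` gives 43 nM. Compound 2 stands level with compounds 1 and 3 at the digits recorded, within the scatter of each.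

Compounds 3 and 1 differ in one place: hydrogen in place of chloro on an aromatic carbon. The step of no change at the digits printed from compound 3 to compound 1 (within the scatter) shows no change within the scatter.

Compound 4 `CCn1cc(C(=O)O)c(=O)c2cc(F)c(N3CCN(C(=N)NS(=O)(=O)c4ccccc4)CC3)cc21` has not yet been measured in this assay. It differs from compound 2 in one place: hydrogen in place of chloro on an aromatic carbon. This is the same kind of change as from compound 3 to compound 1, though the surroundings differ: in compound 3 the chloro is meta to a large group, in compound 2 it is ortho to a large group. The difference between the core of compound 2 and the core of compound 3 is not broken down here.

Compound 4 is expected to give 43 nM in this assay, with a range from 20 nM to 95 nM. The estimated step of no change at the digits printed from compound 2 to compound 4 (within the scatter) is expected to be flat, because the earlier step of no change at the digits printed from compound 3 to compound 1 (within the scatter) was flat and because compound 2 gives 43 nM, level with compound 1 and compound 3. Among the compounds with values here, the different placement of the chloro around the ring leaves some room for deviation, so the range is kept wider than the single measured step would suggest.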

Compound 4, half-maximal inhibitory concentration: 43 nM
Compound 4: middle estimate and measured number agree at the digits printed; the range from low to high includes it.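

In this assay, hydrogen in place of chloro gives no change at the digits printed from compound 2 to compound 4 (within the scatter), and ethyl in place of cyclopropyl on the aromatic nitrogen gives no change at the digits printed from compound 1 to compound 4 (within the scatter). Removing the chloro therefore reads the same on both cores, with compound 2 going to compound 4 matching the earlier pair on the cyclopropyl core: the same change on two cores in this assay, no change at the digits printed (within the scatter) from compound 3 to compound 1 and no change at the digits printed (within the scatter) from compound 2 to compound 4, 1.0-fold (0.00 log units) apart, within the scatter of two such steps What repeats here is a flat step among four compounds that all stand level, which does not show that a step of measurable size would carry from one core to the other; the chloro also sits differently in compound 2 and compound 3, leaving the effect of the core and that of the chloro's placement unseparated.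

Still open, from the compounds shown here alone, is whether a methoxy, nitro, trifluoromethyl or amine group on the phenyl ring of the sulfonyl part, in place of the hydrogen or chloro seen here, would move the value away from that of compound 4. Equally open, going by these compounds, is how a longer chain such as butyl on the aromatic nitrogen, or an ester in place of the carboxylic acid, would read in this assay.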